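Cyclopentyl to Phenyl on the Amide Carbonyl

This account rests on a few compounds, and the source may have more. Where it says the series, first, only, none or still open, it means among the compounds named here.

Compound 1 `O=C(C1CC1)N1CCCn2nc(COc3ccccc3)cc21` and compound 2 `O=C(C1CCCC1)N1CCCn2nc(COc3ccccc3)cc21` share one core and differ only in the ring attached to the carbonyl carbon. In a functional assay on HEK293 cells for positive allosteric modulation of metabotropic glutamate receptor 5 (Homo sapiens), read by calcium flux (on this read-out lower numbers stand for smaller maximal responses and higher numbers for larger maximal responses), compound 1 gives 61%, while compound 2 gives 41%, the lower of the two numbers measured. For the measured compounds named here, the single measured step, a number 20 percentage points lower from compound 1 to compound 2 (beyond the scatter), shows that exchanging the smaller carbon ring for a larger one lowered the maximal response. Compound 3 `O=C(c1ccccc1)N1CCCn2nc(COc3ccccc3)cc21` carries the change (phenyl in place of cyclopentyl on a carbonyl carbon). Going by the values given here, no measured step covers this exact exchange; the only guide is a number 20 percentage points lower from compound 1 to compound 2 (beyond the scatter), a modest drop when the ring grew. A ring of similar size enters here, so compound 3 is expected to land near compound 2 or somewhat lower, with a wide range. Compound 3 is estimated at 38% in this assay, between 18% and 62%. This corresponds to an expected step of a number 3 percentage points lower from compound 2 to compound 3 (within the scatter).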

Compound 3, largest response reached (reported as percent of maximum), in percent of the reference or control that the assay uses: 63%
For compound 3 the middle estimate is 25 percentage points below the measured one, outside the stated range (above it).
By their numbers in this assay, from the lowest: compound 2; then compounds 1 and 3 (each within the scatter of the next).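

In this assay the exchange gives a number 22 percentage points higher from compound 2 to compound 3 (beyond the scatter) and so the drop seen with cyclopentyl is not a simple penalty for any larger ring on this carbonyl carbon. Phenyl and cyclopropyl show a number 2 percentage points higher from compound 1 to compound 3 (within the scatter) and compound 2 is the one that falls away from them, so among these three compounds ring size alone does not set the order of the maximal responses. The data shown offer no explanation for the gap between the phenyl and cyclopentyl rings.

From the compounds shown here alone, whether a cyclohexyl ring would follow cyclopentyl or phenyl remains open, as does the outcome for a pyridine ring or a phenyl ring carrying a chlorine or a methoxy group. These numbers also describe only the largest response, leaving open how much of each compound is needed to reach it.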